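The source may hold more compounds than are shown below. What is called first, only, known or untested is meant among the compounds shown, and "the series" means these compounds.

Measured compounds:
Compound 1 `CCOc1cc(NC(=O)C2(NC(=O)c3ccc4c(C5CCCC5)c(-c5ncc(Cl)cn5)n(C)c4c3)CCC2)ccc1/C=C/C(=O)OC(=O)C[C@H](O)C(=O)O` gives 5.57 h in an ADME assay (liver) for pharmacokinetics, with Liver microsome (Homo sapiens) as the target, using microsomes; a lower number here means that the compound disappears faster, a higher number that the compound lasts longer.
Compound 2 `CCOc1cc(NC(=O)C2(NC(=O)c3ccc4c(C5CCCC5)c(-c5ncc(Cl)cn5)n(C)c4c3)CCC2)ccc1/C=C/C(=O)OCOP(=O)(O)OC(C)(C)C` gives 1.48 h in this assay.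
Compound 3 `CCOc1cc(NC(=O)C2(NC(=O)c3ccc4c(C5CCCC5)c(-c5ncc(Cl)cn5)n(C)c4c3)CCC2)ccc1/C=C/C(=O)OCC(Cl)(Cl)Cl` gives only a limit of the assay, > 5 h, in this assay.

Compound 3 therefore has no exact number, only the limit at which it sits (the limit of > 5 h in this assay, at which 1 of the 3 values shown sits). Compound 4 `CCOc1cc(NC(=O)C2(NC(=O)c3ccc4c(C5CCCC5)c(-c5ncc(Cl)cn5)n(C)c4c3)CCC2)ccc1/C=C/C(=O)OCC(=O)OC` differs from compound 3 by methoxycarbonyl in place of trichloromethyl on a saturated chain carbon bound to an oxygen next to a carbonyl group. Earlier exchanges at the same position moved the half-life by modest amounts: a 3.8-fold lower number from compound 1 to compound 2 (0.58 log units; beyond the scatter), and an at least 3.3-fold higher number from compound 2 to compound 3 (0.52 log units; beyond the scatter), while a step that the limit leaves unreadable from compound 1 to compound 3. Since compound 3 sits at the limit, and exchanges of this group have so far shifted the number modestly, a modest drop from that limit is expected: an at least 2.0-fold lower number from compound 3 to compound 4 (0.30 log units; that floor lies within the scatter). Compound 4 is estimated at 2.5 h, with a likely range from 1 h to 6 h.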

Compound 4, half-life: 2.1 h
The estimate for compound 4 lay 1.2-fold (0.08 log units) above the measured number; low and high end bracket the measured number.
By their numbers in this assay, from the lowest: compounds 2 and 4 (each within the scatter of the next); then compound 1.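

In this assay, methoxycarbonyl in place of trichloromethyl on this saturated chain carbon gives an at least 2.3-fold lower number from compound 3 to compound 4 (0.37 log units; beyond the scatter), so two groups with the same heavy-atom count can still differ clearly. Compound 3 has only a limit of the assay, so this step gives just a floor: the limit of > 5 h in this assay, at which 1 of the 4 values shown sits. Two further steps place compound 4 among the others: a 1.4-fold higher number from compound 2 to compound 4 (0.15 log units; within the scatter), and a 2.7-fold lower number from compound 1 to compound 4 (0.42 log units; beyond the scatter). Still open, from the compounds shown here alone, are how an amine or a longer chain on this carbon would behave, and how far compound 3 truly lies beyond its limit.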